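The compounds below may be only part of what the source reports. "The series", "measured", "known", "first", "only" and "open" are said of these compounds alone.

Values so far in a functional assay on NCI-H23 cells (Homo sapiens) for cytotoxicity, read by sulforhodamine B assay, with a stated time of 72 h (a higher number here means a weaker inhibitor of growth, a lower number a stronger inhibitor of growth), for the series:
- compound 1 `O=C(Nc1ccccc1O)C1CCc2ccccc2N1C(=O)c1ccccc1Cl` gives 46900 nM
- compound 2 `O=C(Nc1ccc(O)cc1)c1ccc2ccccc2n1` gives 102000 nM
- compound 3 `CCCC(=O)N1c2ccccc2CCC1C(=O)Nc1ccccc1C(F)(F)F` gives > 70000 nM as a limit
- compound 4 `CCC(=O)N1c2ccccc2CCC1C(=O)Nc1ccccc1C(F)(F)F` has no value yet

Compound 3 is held only as a limit, > 70000 nM, and not as a number. All that stands for it is the limit of > 70000 nM in this assay, at which 1 of the 3 values shown sits, and no exact position can be given. The two numbers beside it, compound 1 at 46900 nM and compound 2 at 102000 nM, show weak growth inhibition in this assay for both.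

Compound 4 carries hydrogen in place of methyl on a saturated chain carbon, two bonds along the chain from a carbonyl carbon, so that propylcarbonyl becomes propanoyl: hydrogen in place of methyl on a saturated chain carbon, two bonds along the chain from a carbonyl carbon and nothing else changes.

Among the measured compounds shown here, no measured pair differs in one place, so no size of step can be read from the data. For so small a change, no step beyond the scatter is expected in this assay, in either direction. The expectation rests on compound 3 alone, whose > 70000 nM is a limit. The estimated move is a step that the limit leaves unreadable from compound 3 to compound 4. Compound 4 may also end up with only a limit. The expected value for compound 4 is 80000 nM, with an estimated range from 40000 nM to 160000 nM in this series.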

Compound 4, concentration for 50% growth inhibition: > 80000 nM
Compound 4: a limit, no number (the forecaster's own chance of this, stated with the estimate: 55%); the middle value lies on the limit itself.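

In this assay compound 3 gives > 70000 nM, which is a limit and not a number. Compound 4 gives > 80000 nM, also a limit. No step can be read between compound 3 and compound 4. The compounds shown leave open whether going from propylcarbonyl to propanoyl changes growth inhibition at all, and in which direction.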